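The compounds below may be only part of what the source reports. "The series", "measured", "known", "first", "only" and "open" are said of these compounds alone.

Measured compounds in an assay (strain Wistar) for inhibition of Fatty-acid amide hydrolase 1 (Rattus norvegicus); on this read-out lower numbers stand for stronger inhibition and higher numbers for weaker inhibition:

- compound 1, `CCCCNC(=O)Oc1cccc(C(=O)c2nc3ccccc3o2)c1`: 54 nM
- compound 2, `O=C(NC1CCCC1)Oc1cccc(C(=O)c2nc3ccccc3o2)c1`: 28 nM
- compound 3, `CCCCNC(=O)Oc1cccc(C(=O)c2nc3ccccc3s2)c1`: 103 nM

Compound 1 and compound 2 share one core and differ by cyclopentyl in place of butyl on an amide-type nitrogen. This change gives a 1.9-fold lower number from compound 1 to compound 2 (0.29 log units; within the scatter). Compound 3 carries a different core; the difference between the two cores is not broken down here. Compound 1 and compound 3 stand within the scatter of each other in this assay, so no order between them is claimed.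

Compound 4, `O=C(NC1CCCC1)Oc1cccc(C(=O)c2nc3ccccc3s2)c1`, has not been measured. It stands to compound 3 as compound 2 stands to compound 1: the change is cyclopentyl in place of butyl on an amide-type nitrogen, the same kind of change as from compound 1 to compound 2, made here on the core of compound 3. Within the data shown here, only one occurrence of this change has been measured, so the expectation rests on that single step alone.

For compound 4 in this assay a step of about a 1.9-fold lower number from compound 3 to compound 4 (0.27 log units; within the scatter) is expected, because compound 3 gives 103 nM and the matching change gave a 1.9-fold lower number from compound 1 to compound 2 (0.29 log units; within the scatter). The estimate for compound 4 is 55 nM, expected to fall between 25 nM and 120 nM.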

Compound 4, half-maximal inhibitory concentration: 47 nM
Estimate against measurement, compound 4: 1.2-fold (0.07 log units) above; the range from low to high includes it.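

In this assay, cyclopentyl in place of butyl on an amide-type nitrogen gives a 2.2-fold lower number from compound 3 to compound 4 (0.34 log units; beyond the scatter), and the two occurrences of this change do not differ in size: the same change on two cores in this assay, a 1.9-fold lower number (0.29 log units; within the scatter) from compound 1 to compound 2 and a 2.2-fold lower number (0.34 log units; beyond the scatter) from compound 3 to compound 4, 1.1-fold (0.06 log units) apart, within the scatter of two such steps. Among these compounds, the change therefore carries from the core of compound 1 to the core of compound 3 with no readable difference in its step, although only the step on the core of compound 3 lies beyond the scatter. This rests on one pair per core and two cores in all, so it does not show that the step would hold on any further core, or for any other group in place of butyl.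

The compounds shown leave open whether a longer chain such as hexyl, or a ring such as cyclohexyl or phenyl, on the amide-type nitrogen would continue the same trend. They also leave open whether the step survives on a core carrying a further substituent such as an amine or a carboxylic acid.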